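A hydroxylated phenyl gives way to a dichlorinated one

A few compounds are considered here, and "the series" means these few. Any claim that something is new, unique, unknown or untested is made for them only; others in the source may bear on it.

Compound 1 `CN(C)CCn1cnnc1-c1cc(Oc2ccc(NC(=O)N/N=C/c3ccc(Cl)cc3)cc2F)ccn1`: 320 nM
Compound 2 `CN(C)CCn1cnnc1-c1cc(Oc2ccc(NC(=O)N/N=C/c3c[nH]c4ccccc34)cc2F)ccn1`: 1630 nM
Compound 3 `Cc1cc(/C=N/NC(=O)Nc2ccc(Oc3ccnc(-c4nncn4CCN(C)C)c3)c(F)c2)cc(C)c1O`: 2010 nM

In a functional assay on NCI-H460 cells (Homo sapiens) for cytotoxicity, read by MTT assay, with a stated time of 72 h (a higher number here means a weaker inhibitor, a lower number a stronger inhibitor), compound 3 gives the highest of the three numbers, though its step of a 1.2-fold higher number from compound 2 to compound 3 (0.09 log units; within the scatter) is within the scatter, while a 6.3-fold higher number from compound 1 to compound 3 (0.80 log units; beyond the scatter) lies beyond it. Compound 4 `CN(C)CCn1cnnc1-c1cc(Oc2ccc(NC(=O)N/N=C/c3ccc(Cl)cc3Cl)cc2F)ccn1` has not been measured. Its change from compound 3 is 2,4-dichlorophenyl in place of 4-hydroxy-3,5-dimethylphenyl on a carbon with a double bond to nitrogen. Going by the values given here, the one measured step that bears on this is a 6.3-fold higher number from compound 1 to compound 3 (0.80 log units; beyond the scatter), taken in reverse: compound 1 carries 4-chlorophenyl and gives 320 nM. Compound 4 carries a chlorinated phenyl again, so a return toward that number is expected. The step is estimated as a 6.1-fold lower number from compound 3 to compound 4 (0.78 log units; beyond the scatter). For compound 4 the expected value is 330 nM, with a range from 110 nM to 1000 nM.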

Compound 4, half-maximal inhibitory concentration: 130 nM
Beside the measured number, compound 4's estimate is 2.5-fold (0.40 log units) above it; the range from low to high includes it.
By their numbers in this assay, from the lowest: compound 4; then compound 1; then compounds 2 and 3 (each within the scatter of the next).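

Adding a second chloro on an aromatic carbon, which turns 4-chlorophenyl into 2,4-dichlorophenyl, gives a 2.5-fold lower number from compound 1 to compound 4 (0.39 log units; beyond the scatter), so a single chlorine did not mark the limit at this position. The wider gaps, a 15-fold lower number from compound 3 to compound 4 (1.19 log units; beyond the scatter) and a 13-fold lower number from compound 2 to compound 4 (1.10 log units; beyond the scatter), set 2,4-dichlorophenyl clearly ahead of both 4-hydroxy-3,5-dimethylphenyl and 1H-indol-3-yl. No measurement at hand explains these steps. Still open, as far as these compounds go, is whether the second chloro's place on the phenyl matters or only its presence, and whether bromo or methoxy there would serve as well.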